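Pentafluorophenyl exchange on the sulfonyl of compound 2

The source may hold more compounds than are shown below. What is called first, only, known or untested is meant among the compounds shown, and "the series" means these compounds.

In a functional assay on SUP-B15 cells (Homo sapiens) for antiproliferative activity, with a stated time of 72 h (a higher number here means that more compound is needed for the effect, a lower number that less compound is needed), compound 1 `COc1ccc(-c2cc(=O)c3c(OC)cc(OC)cc3[nH]2)cc1` gives > 62000 nM, which is a limit of the assay and not a number. Compound 2 `COc1ccc(-c2cc(=O)c3c(OC)cc(OC)cc3n2S(=O)(=O)c2ccc(C=O)cc2)cc1` gives > 34400 nM, again only a limit, so its standing is known only as a limit and no measured potency exists in this small set. Compound 3 `COc1ccc(-c2cc(=O)c3c(OC)cc(OC)cc3n2S(=O)(=O)c2c(F)c(F)c(F)c(F)c2F)cc1` carries 2,3,4,5,6-pentafluorophenyl in place of 4-formylphenyl on a sulfonyl sulfur. For the measured compounds named here, the one measured step bearing on this is a step that the two limits leave unreadable from compound 1 to compound 2, and it offers no size to carry over to the new exchange. No firm direction can therefore be expected in this assay, and another limit is the likeliest report. The expected step is an at least 1.7-fold lower number from compound 2 to compound 3 (0.23 log units; that floor lies within the scatter). Compound 3 is estimated at 20000 nM, with an expected range of 2000 nM to 60000 nM.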

Compound 3, half-maximal effective concentration: 4100 nM
Beside the measured number, compound 3's estimate is 4.9-fold (0.69 log units) above it, within the range that was stated.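

In this assay the group on the sulfonyl sulfur turns out to matter: the exchange gives an at least 8.3-fold lower number from compound 2 to compound 3 (0.92 log units; beyond the scatter), the first step in the series with a readable size, and compound 3 is the only compound shown with a measured number rather than a limit. A sulfonyl on the aromatic nitrogen is therefore compatible with measurable antiproliferative activity when it carries 2,3,4,5,6-pentafluorophenyl. The step remains a floor, because compound 2 stands at a limit of the assay: the limit of > 34400 nM in this assay, at which 1 of the 3 values shown sits.

Going by these compounds, the step from compound 1 to compound 2 cannot be read, as both values are limits, so the contribution of the sulfonyl itself stays open. On these data alone, it is also open whether the change in activity follows the entering fluorines or the departing formyl, a question that a plain phenyl or a phenyl bearing an amine on the sulfonyl sulfur would address.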